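Cyano in Place of Benzoyl on a Sulfonyl Alkene

This account rests on a few compounds, and the source may have more. Where it says the series, first, only, none or still open, it means among the compounds named here.

Measured so far:
Compound 1, `CC(=O)/C(=C\c1c(-c2ccccc2)[nH]c2ccccc12)S(=O)(=O)c1ccccc1`, gives 2400 nM.
Compound 2, `O=C(/C(=C\c1c(-c2ccccc2)[nH]c2ccccc12)S(=O)(=O)c1ccccc1)c1ccccc1`, gives 3500 nM.
Compound 3, `COc1ccc(-c2[nH]c3ccc(OC)cc3c2C=C(C#N)C#N)cc1`, gives 306 nM.

All three numbers come from a functional assay on SF-295 cells (Homo sapiens) for inhibition, read by sulforhodamine B assay, with a stated time of 48 h; on this read-out higher numbers stand for weaker inhibition of growth and lower numbers for stronger inhibition of growth. On those numbers compound 2 stands highest of the three, though its nearest neighbour, compound 1, is within the scatter of it: the step of a 1.5-fold higher number from compound 1 to compound 2 (0.16 log units; within the scatter) goes with phenyl in place of methyl on a carbonyl carbon and does not rise beyond the usual spread. Within the data shown here, compound 3 lies furthest from compound 2, but it differs from compound 2 in more than one place, so only the two values themselves can be compared, and no single step links them.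

Compound 4, `N#C/C(=C\c1c(-c2ccccc2)[nH]c2ccccc12)S(=O)(=O)c1ccccc1`, differs from compound 2 by cyano in place of benzoyl on a double-bonded chain carbon bound to a double-bonded chain carbon and a sulfonyl sulfur. Among the measured compounds shown here, the only measured step that touches the same carbon is the one from compound 1 to compound 2, and it was within the scatter; no measured pair exchanges a carbonyl-bearing group for cyano with everything else held fixed. The group that enters is far smaller than the one that leaves, and the remaining part of the molecule is unchanged. Compound 4 is therefore expected to show a step of modest size, a 1.9-fold lower number from compound 2 to compound 4 (0.29 log units; within the scatter), in this assay, with a lower number slightly favoured. The estimate for compound 4 is 1800 nM, with a range from 500 nM to 6000 nM.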

Compound 4, concentration for 50% growth inhibition: 2400 nM
Compound 4: the middle estimate sits 1.3-fold (0.12 log units) below what was measured; the measured number falls inside the stated range.
By their numbers in this assay, from the lowest: compound 3; then compounds 1, 4 and 2 (each within the scatter of the next).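

In this assay, cyano in place of benzoyl gives a 1.5-fold lower number from compound 2 to compound 4 (0.16 log units; within the scatter) and cyano in place of acetyl gives no change at the digits printed from compound 1 to compound 4 (within the scatter) on the double-bonded chain carbon bound to a double-bonded chain carbon and a sulfonyl sulfur. Among these compounds, the earlier compounds had compared only two carbonyl-bearing groups at this carbon (a 1.5-fold higher number from compound 1 to compound 2 (0.16 log units; within the scatter)), whereas these steps add a group without a carbonyl and with a far smaller heavy-atom count, 2 against 8 for benzoyl. Across compounds 1, 2 and 4, then, acetyl, benzoyl and cyano are not separated by this read-out, and nothing available here offers an explanation for that.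

As far as these compounds go, it remains open whether an amine, a carboxylic acid or a longer chain on this carbon would shift the number beyond the scatter. Compound 3 gives 306 nM but differs from compounds 1, 2 and 4 in more than one place, so which of its differences goes with that number also remains unresolved.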